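A Methyl on the Anilino Ring of Compound 3

The source may hold more compounds than are shown below. What is called first, only, known or untested is meant among the compounds shown, and "the series" means these compounds.

Measured in a functional assay on NCI-H460 cells (Homo sapiens) for cytotoxicity, read by MTT assay; on this read-out higher numbers stand for weaker inhibition and lower numbers for stronger inhibition:
Compound 1, `COc1cc(/C=C/C(=O)c2sc(Nc3ccc(Cl)cc3)nc2C)cc(OC)c1OC`, gives 22000 nM.
Compound 2, `COc1cc(/C=C/C(=O)c2sc(Nc3ccc(F)c(Cl)c3)nc2C)cc(OC)c1OC`, gives 6310 nM.
Compound 3, `COc1cc(/C=C/C(=O)c2sc(Nc3ccccc3)nc2C)cc(OC)c1OC`, gives only a limit of the assay, > 25000 nM.

Compound 3 thus stands not at a number but at the limit of > 25000 nM in this assay, at which 1 of the 3 values shown sits, while compound 1 and compound 2 both lie within the measured range. Compound 4, `COc1cc(/C=C/C(=O)c2sc(Nc3cccc(C)c3)nc2C)cc(OC)c1OC`, differs from compound 3 by methyl in place of hydrogen on an aromatic carbon. Within the data shown here, the steps that bear on this change all concern substituents on the same anilino ring: an at least 1.1-fold higher number from compound 1 to compound 3 (0.05 log units; that floor lies within the scatter), an at least 3.9-fold higher number from compound 2 to compound 3 (0.59 log units; beyond the scatter), and a 3.5-fold lower number from compound 1 to compound 2 (0.54 log units; beyond the scatter). In each case the ring carrying a substituent gave the lower number and the bare ring the higher one. Among the measured compounds shown here, no measured compound carries a methyl on that ring, so the size of the effect of this particular group is unknown. He therefore expects a modest lowering, an at least 1.6-fold lower number from compound 3 to compound 4 (0.22 log units; that floor lies within the scatter), with wide uncertainty. Compound 4 is estimated at 15000 nM, in a range from 5000 nM to 40000 nM.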

Compound 4, half-maximal inhibitory concentration: 19800 nM
Estimate against measurement, compound 4: 1.3-fold (0.12 log units) below; the range from low to high includes it.
By their numbers in this assay, from the lowest: compound 2; then compounds 4 and 1 (each within the scatter of the next). At a limit, above all of these: compound 3.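

In this assay, methyl on the bare anilino ring gives an at least 1.2-fold lower number from compound 3 to compound 4 (0.10 log units; that floor lies within the scatter), so this change has not been shown to lower the number by more than the usual scatter. The 3-methylphenyl and 4-chlorophenyl rings cannot be told apart, at a 1.1-fold lower number from compound 1 to compound 4 (0.05 log units; within the scatter), so neither single substituent has a demonstrated effect on the bare ring. Among the rings shown, the 3-chloro-4-fluorophenyl ring alone stands clearly apart, with a 3.1-fold higher number from compound 2 to compound 4 (0.50 log units; beyond the scatter).

As far as these compounds go, how far methyl truly moves the number remains open because the value of compound 3 is only a limit: the limit of > 25000 nM in this assay, at which 1 of the 4 values shown sits. Also open, from the compounds shown here alone, is whether a methoxy, a trifluoromethyl or an amine in the place of this methyl would come closer to compound 2, or whether its two halogens must act together.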